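Fluoro to amino on a shared core near the limit

This account rests on a few compounds, and the source may have more. Where it says the series, first, only, none or still open, it means among the compounds named here.

Compound 1 `COc1ccc(-c2nc3cccc(-c4cc(OC)c(OC)c(OC)c4)c3o2)cc1` and compound 2 `COc1cc(-c2cccc3nc(-c4ccc(F)cc4)oc23)cc(OC)c1OC` share one core. In a functional assay on U-251 cells (Homo sapiens) for antiproliferative activity, read by MTT assay, with a stated time of 48 h (on this read-out higher numbers stand for weaker inhibition and lower numbers for stronger inhibition), compound 1 gives > 25000 nM, which is a limit of the assay and not a number. In this assay compound 2 gives > 25000 nM, likewise a limit rather than a number. Both values sit at the limit of > 25000 nM in this assay, at which 2 of the 2 values shown sit, so the step that the two limits leave unreadable from compound 1 to compound 2, fluoro in place of methoxy on an aromatic carbon, carries no readable size. Compound 2 therefore stands at the limit, and no numbered value exists among the two compounds measured.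

Compound 3 `COc1cc(-c2cccc3nc(-c4ccc(N)cc4)oc23)cc(OC)c1OC` differs from compound 2 by amino in place of fluoro on an aromatic carbon. No measured step bears on this change: the single step shown is unreadable, and neither measured compound supplies a number from which a size or a direction could be taken. One therefore expects no step beyond the scatter and a value that most likely remains at the limit. For compound 3 the estimate in this assay is 30000 nM, between 5000 nM and 100000 nM. The step this estimate implies, a step that the limit leaves unreadable from compound 2 to compound 3, is an expectation only.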

Compound 3, half-maximal inhibitory concentration: 1040 nM
Compound 3: the middle estimate sits 29-fold (1.46 log units) above what was measured, outside the stated range (below it).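

In this assay, the change from 4-fluorophenyl to 4-aminophenyl gives an at least 24-fold lower number from compound 2 to compound 3 (1.38 log units; beyond the scatter), which shows that this place, para to a large group, can separate compounds on the shared core by more than the scatter. The amino group also stands apart from the methoxy group at the same place, with an at least 24-fold lower number from compound 1 to compound 3 (1.38 log units; beyond the scatter). The earlier pair could not show this, since the step between its two members cannot be read and each new step is only a minimum set by the limit on its starting compound: the limit of > 25000 nM in this assay, at which 2 of the 3 values shown sit.

The compounds shown leave open whether the large step belongs to the amino group alone or extends to other groups at this place, such as a hydroxyl, a dimethylamino or an acetamido group. They also leave open how much further the number moves with such groups, and whether the amino group would have a step of similar size if the trimethoxyphenyl group on the shared core were replaced by a plain phenyl group.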